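A Second Methoxy Added to a Compound with an Already High Number

The source may hold more compounds than are shown below. What is called first, only, known or untested is meant among the compounds shown, and "the series" means these compounds.

For the measured compounds named here, compound 2 `COc1ccc(/C=C/C(=O)c2ccc3occc3c2O)cc1` stands highest of the two numbers measured so far, giving 94.8% in an assay on isolated protein for inhibition of lysosomal alpha-glucosidase (Rattus norvegicus), read by spectrophotometry, with a stated time of 5 min, tested at 25 ug/mL; on this read-out lower numbers stand for less inhibition and higher numbers for more inhibition at the one concentration tested (going by the name of the read-out). Compound 1 `O=C(/C=C/c1ccccc1)c1ccc2occc2c1O` gives 20.8%. Going by the values given here, the one step measured, a number 74 percentage points higher from compound 1 to compound 2 (beyond the scatter), was large. Compound 3 `COc1ccc(/C=C/C(=O)c2ccc3occc3c2O)cc1OC` repeats the same kind of change: methoxy in place of hydrogen on an aromatic carbon. Among the compounds with values here, that earlier step is the only guide, yet compound 2 already sits near the top of the percentage scale, leaving little room for a further rise. The expected step is therefore small, within the scatter: a number 2.8 percentage points lower from compound 2 to compound 3 (within the scatter). Compound 3 is expected to give 92%, with a range from 75% to 99%.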

Compound 3, a percentage reported as inhibition, at one concentration (the size of the read-out at that concentration, not a potency): 89.5%
The estimate for compound 3 lay 2.5 percentage points above the measured number, within the range that was stated.
By their numbers in this assay, from the lowest: compound 1; then compounds 3 and 2 (each within the scatter of the next).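

At this position, ortho to a methoxy group and meta to a large group, the added methoxy gave a number 5.3 percentage points lower from compound 2 to compound 3 (within the scatter) in this assay. The large rise seen with the first methoxy therefore did not repeat here, although a number already so near the top of the percentage scale leaves little room to show a rise. No measurement available here explains this result.

Going by these compounds, it remains open whether an amine or a carboxylic acid at this position would keep the number this high. A single tested concentration also leaves open whether compound 2 and compound 3 would separate at lower concentrations.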